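Methoxy in place of trifluoromethyl: what to expect

The source may report more compounds than this note shows. Statements on the series, on what has been measured and on what is new or still open speak of the compounds shown alone.

Compound 3 `C=C1C(=O)[C@]23C[C@@]1(O)CC[C@H]2c1ccc(O)c(C)c1[C@@H]3Cn1cc(-c2ccc(C(F)(F)F)cc2)nn1` gives 1440 nM in a functional assay on SMMC-7721 cells (Homo sapiens) for cytotoxicity, read by MTT assay, with a stated time of 4 days; on this read-out higher numbers stand for weaker inhibition and lower numbers for stronger inhibition. This is the higher of the two numbers measured. Its nearest neighbour, compound 2 `C=C1C(=O)[C@]23C[C@@]1(O)CC[C@H]2c1ccc(O)c(C)c1[C@@H]3Cn1cc(-c2ccc(F)cc2)nn1`, gives 850 nM. The step between them reads a 1.7-fold higher number from compound 2 to compound 3 (0.23 log units; within the scatter). Compound 1 `Cc1c(O)ccc2c1[C@H](Cn1cc(-c3ccccn3)nn1)[C@@]13CC(=O)[C@@](C)(CC[C@@H]21)C3` is reported only as a limit of the measurement, > 20000 nM. Compound 4 `C=C1C(=O)[C@]23C[C@@]1(O)CC[C@H]2c1ccc(O)c(C)c1[C@@H]3Cn1cc(-c2ccc(OC)cc2)nn1` differs from compound 3 by methoxy in place of trifluoromethyl on an aromatic carbon. Among the measured compounds shown here, the only measured step that bears on a change of this group is a 1.7-fold higher number from compound 2 to compound 3 (0.23 log units; within the scatter), which lay within the scatter, and no measured compound carries a methoxy there. One therefore expects no step beyond the scatter, estimated as a 1.2-fold lower number from compound 3 to compound 4 (0.08 log units; within the scatter). Compound 4 is expected to give 1200 nM, with a range from 450 nM to 3500 nM.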

Compound 4, half-maximal inhibitory concentration: 860 nM
Beside the measured number, compound 4's estimate is 1.4-fold (0.14 log units) above it, within the range that was stated.
By their numbers in this assay, from the lowest: compounds 2, 4 and 3 (each within the scatter of the next). At a limit, above all of these: compound 1.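

In this assay, methoxy in place of trifluoromethyl gives a 1.7-fold lower number from compound 3 to compound 4 (0.22 log units; within the scatter), and methoxy in place of fluoro gives a 1.0-fold higher number from compound 2 to compound 4 (0.01 log units; within the scatter). Three groups, rather than the earlier two, have now been read on this aromatic carbon para to a large group, and compounds 2, 3 and 4 all stand within the scatter of each other, even with the hydrogen-bond acceptor that enters with methoxy. Nothing at hand bears on why these groups read alike. Going by these compounds, whether an amine or a carboxylic acid on this carbon would move the number beyond the scatter remains open.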